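A few compounds are considered here, and "the series" means these few. Any claim that something is new, unique, unknown or untested is made for them only; others in the source may bear on it.

The series shares one core and is varied only in the aryl group on the carbonyl carbon. In an assay for inhibition of Maternal embryonic leucine zipper kinase (Homo sapiens), read by ADP-Glo, with a stated time of 0.5 h (a higher number here means a weaker inhibitor, a lower number a stronger inhibitor), compound 1 `CC(C)Nc1sc(C(=O)c2cccc(C#N)c2)c(N)c1C#N` gives > 5000 nM, which is a limit of the assay rather than a number. Compound 2 `CC(C)Nc1sc(C(=O)c2cccnc2)c(N)c1C#N` likewise sits at a limit in this assay, with > 5000 nM. Within the data shown here, compound 3 `CC(C)Nc1sc(C(=O)c2ccco2)c(N)c1C#N` is the one member with a measured number in this assay, 1350 nM. Two of the three values therefore sit at the limit of > 5000 nM in this assay, at which 2 of the 3 values shown sit, so compound 2 stands only at the weak end of what this assay resolves, with no number of its own. Among the measured compounds shown here, the single measured step that bears on the present change is an at least 3.7-fold lower number from compound 2 to compound 3 (0.56 log units; beyond the scatter), and it runs toward stronger inhibition.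

Compound 4 `CC(C)Nc1sc(C(=O)c2cc(Cl)cs2)c(N)c1C#N` is not yet measured in this assay. Its change from compound 2 is 4-chlorothiophen-2-yl in place of pyridin-3-yl on a carbonyl carbon. As in the step to compound 3, a six-membered aromatic ring with one hetero atom gives way to a five-membered aromatic ring with one hetero atom, so a step of the same direction and at least modest size is expected, an at least 4.1-fold lower number from compound 2 to compound 4 (0.61 log units; beyond the scatter). Compound 4 is accordingly expected to give about 1200 nM in this assay, within 300 nM to 5000 nM, with some chance that only a limit is returned.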

Compound 4, half-maximal inhibitory concentration: 575 nM
Beside the measured number, compound 4's estimate is 2.1-fold (0.32 log units) above it; the measured number falls inside the stated range.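

In this assay, among these compounds, the change to 4-chlorothiophen-2-yl on the carbonyl carbon gives an at least 8.6-fold lower number from compound 2 to compound 4 (0.93 log units; beyond the scatter), so furan-2-yl is no longer the only group at this place with a measured number. Across the four compounds, both five-membered aromatic rings (compound 3, compound 4) now return numbers, while both six-membered rings (compound 1, compound 2) stay at a limit, and no compound shown goes against this split; the five-membered rings also differ from each other, with a 2.3-fold lower number from compound 3 to compound 4 (0.37 log units; beyond the scatter). The step from compound 2 can be read only as a bound, because compound 2 has no number of its own: the limit of > 5000 nM in this assay, at which 2 of the 4 values shown sit.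

The change from furan-2-yl to 4-chlorothiophen-2-yl swaps the ring hetero atom and brings in chlorine in one move, and the compounds shown cannot divide the step between the two. Also open, from the compounds shown here alone, is how a thiophen-2-yl without chlorine would read, or one carrying a methyl or an amine in place of the chlorine.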